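(Piperidin-1-yl)carbonyl in place of (piperidin-1-yl)methyl

The source may report more compounds than this note shows. Statements on the series, on what has been measured and on what is new or still open speak of the compounds shown alone.

Compound 3 `Fc1cccc(COc2ccc(Nc3ncnc4ccc(-c5cccc(CN6CCCCC6)c5)cc34)cc2Cl)c1` has no number to start from: in an ADME assay on HepG2 cells (Homo sapiens) for cytotoxicity, read by MTT assay, with a stated time of 48 h (a lower number here means a stronger inhibitor, a higher number a weaker inhibitor), compound 3 stands as "not determined" (no result reported). Compound 1 `O=S(=O)(c1cccc(-c2ccc3ncnc(Nc4ccc(OCc5cccc(F)c5)c(Cl)c4)c3c2)c1)N1CCOCC1` gives > 15000 nM in this assay, which is a limit of the assay and not a number. Compound 2 `O=S(=O)(c1cccc(-c2ccc3ncnc(Nc4ccc(OCc5cccc(F)c5)c(Cl)c4)c3c2)c1)N1CCCC1` gives > 15000 nM, likewise a limit. Among the compounds with values here, the only measured step is a step that the two limits leave unreadable from compound 1 to compound 2, so it supplies no size to carry over.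

Compound 4 `O=C(c1cccc(-c2ccc3ncnc(Nc4ccc(OCc5cccc(F)c5)c(Cl)c4)c3c2)c1)N1CCCCC1` differs from compound 3 by (piperidin-1-yl)carbonyl in place of (piperidin-1-yl)methyl on an aromatic carbon, with (piperidin-1-yl)carbonyl in place of (piperidin-1-yl)methyl on an aromatic carbon. Within the data shown here, no step from compound 3 can be sized, and the expectation rests only on (the limit of > 15000 nM in this assay, at which 2 of the 3 values shown sit). For compound 4 the expected value is 20000 nM, with an estimated range of 8000 nM to 50000 nM.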

Compound 4, half-maximal inhibitory concentration: > 6000 nM
Compound 4 was reported as a limit; the forecaster's own chance of this, stated with the estimate: 65%; the middle value does not contradict the limit.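

In this assay compound 4 gives > 6000 nM, a limit of the assay and not a number, so its steps from compound 1 and compound 2 cannot be read. The compounds shown leave open how (piperidin-1-yl)carbonyl compares with (piperidin-1-yl)methyl.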